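Taking the phenyl group off compound 3

A few compounds are considered here, and "the series" means these few. Any claim that something is new, unique, unknown or untested is made for them only; others in the source may bear on it.

Measured compounds in a functional assay on KG-1 cells (Homo sapiens) for cytotoxicity, read by luminescence and CellTiter-Glo, with a stated time of 3 days; a lower number here means a stronger inhibitor, a higher number a weaker inhibitor:
Compound 1 `N#Cc1ccc(NC(=O)c2cc(F)ccc2O)cc1`: 2670 nM
Compound 2 `N#Cc1ccc(NC(=O)c2cc(-c3cccnc3)ccc2O)cc1`: 8330 nM
Compound 3 `N#Cc1ccc(NC(=O)c2cc(Br)c(-c3ccccc3)cc2O)cc1`: 850 nM

Compound 3 has the lowest number of the three, and its gaps to compound 1 and compound 2 both lie beyond the scatter. Compound 4 `N#Cc1ccc(NC(=O)c2cc(Br)ccc2O)cc1` departs from it by one change, hydrogen in place of phenyl on an aromatic carbon. Within the data shown here, only one measured step offers any guide, and it is a 3.1-fold higher number from compound 1 to compound 2 (0.49 log units; beyond the scatter). That step put pyridin-3-yl in place of fluoro, so it is no direct match, and there an incoming aromatic ring went with a higher number. Among the measured compounds shown here, no measured pair isolates the phenyl group. Even so, compound 3 gives 850 nM and compound 1 gives 2670 nM, so a modest move to a higher number in this assay is expected, though the direction is uncertain. The expected change is a 2.0-fold higher number from compound 3 to compound 4 (0.30 log units; within the scatter). For compound 4 the estimated value is 1700 nM, with an expected range of 600 nM to 5000 nM.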

Compound 4, half-maximal inhibitory concentration: 1290 nM
Beside the measured number, compound 4's estimate is 1.3-fold (0.12 log units) above it, within the range that was stated.
By their numbers in this assay, from the lowest: compounds 3 and 4 (each within the scatter of the next); then compound 1; then compound 2.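

In this assay, hydrogen in place of phenyl on the aromatic carbon ortho to a bromo group and meta to a hydroxy group gives a 1.5-fold higher number from compound 3 to compound 4 (0.18 log units; within the scatter), so the phenyl group at this position has no effect that can be told from the scatter. The bromo group gives the clearer readings, with bromo in place of pyridin-3-yl giving a 6.5-fold lower number from compound 2 to compound 4 (0.81 log units; beyond the scatter) and bromo in place of fluoro giving a 2.1-fold lower number from compound 1 to compound 4 (0.32 log units; beyond the scatter), both beyond the scatter. No available evidence accounts for these differences.

The compounds shown leave open how a methyl group, an amine or a carboxylic acid on the carbon that carries phenyl in compound 3 would read. They also leave open whether phenyl at that carbon would read the same with hydrogen in place of the bromo group.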